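The compounds below may be only part of what the source reports. "The series", "measured", "known", "first", "only" and "open" are said of these compounds alone.

Compound 1 `O=C(O)c1ccc2noc(-c3ccc(-c4ccncc4)cc3)c2c1` gives 150 nM in an assay for inhibition of inositol hexakisphosphate kinase 2 (Homo sapiens), read by colorimetric assay, coupled enzyme assay and malachite green, with a stated time of 120 min, in the presence of a further agent that is not named here; on this read-out lower numbers stand for stronger inhibition and higher numbers for weaker inhibition. Compound 2 `O=C(O)c1ccc2noc(-c3ccc(N4CCCCC4)cc3)c2c1` gives 240 nM in this assay, with a 1.6-fold higher number from compound 1 to compound 2 (0.20 log units; within the scatter). Compound 3 `O=C(O)c1ccc2noc(-c3ccc(Oc4ccccn4)cc3)c2c1` gives 1190 nM in this assay and carries the highest number of the three: a 7.9-fold higher number from compound 1 to compound 3 (0.90 log units; beyond the scatter) and a 5.0-fold higher number from compound 2 to compound 3 (0.70 log units; beyond the scatter). Compound 4 `CC(C)C(=O)Nc1ccc(-c2onc3ccc(C(=O)O)cc23)cc1` differs from compound 3 in one place: (isopropylcarbonyl)amino in place of (pyridin-2-yl)oxy on an aromatic carbon. Going by the values given here, no measured step introduces this amide, so the two steps ending at compound 3 are the only guide; both show that the group now leaving gave the weakest result. Given that a 7.9-fold higher number from compound 1 to compound 3 (0.90 log units; beyond the scatter) and a 5.0-fold higher number from compound 2 to compound 3 (0.70 log units; beyond the scatter) both lie beyond the scatter, the expected outcome is a 4.0-fold lower number from compound 3 to compound 4 (0.60 log units; beyond the scatter), with size uncertain. Compound 4 is estimated at 300 nM in this assay, range 90 nM to 1000 nM.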

Compound 4, half-maximal inhibitory concentration: 820 nM
Beside the measured number, compound 4's estimate is 2.7-fold (0.44 log units) below it; measured number inside the range.
By their numbers in this assay, from the lowest: compounds 1 and 2 (each within the scatter of the next); then compounds 4 and 3 (each within the scatter of the next).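

Replacing the ring-bearing (pyridin-2-yl)oxy with the ringless (isopropylcarbonyl)amino leaves the number within the scatter, a 1.5-fold lower number from compound 3 to compound 4 (0.16 log units; within the scatter), while the amide stays apart from the two lowest entries, with a 3.4-fold higher number from compound 2 to compound 4 (0.53 log units; beyond the scatter) and a 5.5-fold higher number from compound 1 to compound 4 (0.74 log units; beyond the scatter). Among these four compounds, the two groups with a ring attached directly, pyridin-4-yl and piperidin-1-yl, give lower numbers than the two attached through a linking atom. No available evidence accounts for these differences. On these data alone, whether a phenyl ring, a morpholine or a plain amine at this position would give a number close to that of compound 1 stays open.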